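The compounds below may be only part of what the source reports. "The series", "measured", "known", "first", "only" and "open" are said of these compounds alone.

The measured compounds:
Compound 1, `O=C1CS/C(=N\c2csc(-c3ccc(Cl)cc3)c2)N1`, in a functional assay on HCT-116 cells (Homo sapiens) for cytotoxicity, read by MTT assay, with a stated time of 72 h (on this read-out higher numbers stand for weaker inhibition and lower numbers for stronger inhibition), gives > 50000 nM, which is a limit of the assay rather than a number.
Compound 2, `O=C1N/C(=N/c2csc(-c3ccc(Cl)cc3)c2)S/C1=C\c1ccccc1`, gives 11200 nM.
Compound 3, `Cc1ccc(/C=C2\S/C(=N\c3csc(-c4ccc(Cl)cc4)c3)NC2=O)cc1`, gives 1000 nM.

Within the data shown here, compound 3 holds the lowest of the two numbers; its nearest neighbour is compound 2, and the single step between them, an 11-fold lower number from compound 2 to compound 3 (1.05 log units; beyond the scatter), is large and clearly beyond the scatter. Compound 1 sits at the limit of > 50000 nM in this assay, at which 1 of the 3 values shown sits, so its gap to the others cannot be sized.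

Compound 4, `O=C1N/C(=N/c2csc(-c3ccc(Cl)cc3)c2)S/C1=C\c1ccc2ccccc2c1`, differs from compound 3 by naphthalen-2-yl in place of 4-methylphenyl on a double-bonded chain carbon bound to a double-bonded ring carbon. Among the measured compounds shown here, only one measured step touches this position, the change from compound 2 to compound 3, where enlarging the aromatic group on the double-bonded chain carbon gave a large gain. Extending that group once more is therefore expected to hold or modestly improve the number, giving a 1.7-fold lower number from compound 3 to compound 4 (0.22 log units; within the scatter). Compound 4 is estimated at 600 nM, within a range from 150 nM to 3000 nM.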

Compound 4, half-maximal inhibitory concentration: 3000 nM
Compound 4: middle estimate off by 5.0-fold (0.70 log units), on the low side; the range from low to high includes it.
By their numbers in this assay, from the lowest: compound 3; then compound 4; then compound 2. At a limit, above all of these: compound 1.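

In this assay, size alone does not set the number at this position, the double-bonded chain carbon bound to a double-bonded ring carbon. Replacing 4-methylphenyl with naphthalen-2-yl gives a 3.0-fold higher number from compound 3 to compound 4 (0.48 log units; beyond the scatter), so the larger group with its second aromatic ring gives up part of the gain seen earlier. Naphthalen-2-yl still improves on plain phenyl, with a 3.7-fold lower number from compound 2 to compound 4 (0.57 log units; beyond the scatter), so the position accepts the larger group, but the best of these three groups is the mid-sized 4-methylphenyl, not the largest.

Nothing measured in this set explains why 4-methylphenyl does better than naphthalen-2-yl. Still open, going by these compounds, is how a phenyl ring carrying an amine, a carboxylic acid or a longer carbon chain in place of the methyl would fare on this carbon.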